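Halogen Swap Tested Twice on Two Related Cores

This account rests on a few compounds, and the source may have more. Where it says the series, first, only, none or still open, it means among the compounds named here.

Compound 1 `Nc1cccc(/C=C2\SC(=O)N(Cc3ccc(F)cc3)C2=O)c1` and compound 2 `Nc1cccc(/C=C2\SC(=O)N(Cc3cccc(Cl)c3)C2=O)c1` share a core and differ in one place: 3-chlorophenyl in place of 4-fluorophenyl on a saturated chain carbon bound to an amide-type nitrogen in a ring. In a functional assay on L1210 cells (Mus musculus) for cytotoxicity, read by cell counting, with a stated time of 2 days (a higher number here means a weaker inhibitor, a lower number a stronger inhibitor), compound 1 gives 142000 nM, and compound 2 gives 211000 nM, so the change made a 1.5-fold higher number from compound 1 to compound 2 (0.17 log units; within the scatter). Compound 3 `C=C(Br)C(=O)Nc1ccc(/C=C2\SC(=O)N(Cc3ccc(F)cc3)C2=O)cc1` rests on a different core; how its core differs from that of compound 1 is not broken down here. In this assay compound 3 gives 2200 nM, the lowest of the three numbers, and its distance to compound 1 and compound 2 lies beyond the scatter in both cases. Compound 4 `C=C(Br)C(=O)Nc1ccc(/C=C2\SC(=O)N(Cc3cccc(Cl)c3)C2=O)cc1` has not yet been measured. It differs from compound 3 by 3-chlorophenyl in place of 4-fluorophenyl on a saturated chain carbon bound to an amide-type nitrogen in a ring, the same change as that between compound 1 and compound 2, and at a place described in the same words. Because the earlier instance of this change made only a 1.5-fold higher number from compound 1 to compound 2 (0.17 log units; within the scatter), the step from compound 3 to compound 4 is expected to be of similar size, a 1.4-fold higher number from compound 3 to compound 4 (0.13 log units; within the scatter), an expectation that rests on a single prior example. Compound 4 is therefore expected to give about 3000 nM in this assay, estimated to fall between 1200 nM and 8000 nM.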

Compound 4, half-maximal inhibitory concentration: 3400 nM
The estimate for compound 4 lay 1.1-fold (0.05 log units) below the measured number; the measured number falls inside the stated range.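

On the core of compound 3, 3-chlorophenyl in place of 4-fluorophenyl made a 1.5-fold higher number from compound 3 to compound 4 (0.19 log units; within the scatter) in this assay. Set beside the earlier instance, the change looks the same on both cores in this assay: the same change on two cores in this assay, a 1.5-fold higher number (0.17 log units; within the scatter) from compound 1 to compound 2 and a 1.5-fold higher number (0.19 log units; within the scatter) from compound 3 to compound 4, 1.0-fold (0.02 log units) apart, within the scatter of two such steps

This shows that, on these two cores, the swap left the number within the scatter, so neither pair separates the two benzyl groups; it does not show that the same would hold on a third core, in another assay, or for another pair of groups, and two pairs make no general rule.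

The compounds shown leave open whether a plain benzyl, a 4-methoxybenzyl or a longer chain ending in a carboxylic acid would also leave the number in place on the same nitrogen. They also leave open which part of the core of compound 3 matters for its number in this assay, for instance whether an acetamide could stand in for the bromine-bearing amide.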